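A few compounds are considered here, and "the series" means these few. Any claim that something is new, unique, unknown or untested is made for them only; others in the source may bear on it.

Measured compounds:
Compound 1, `O=C(Nc1ccc(Oc2ccnc3[nH]ccc23)c(F)c1)c1cc2cccnc2n(-c2ccc(Cl)cc2)c1=O`, in a functional assay on HT-29 cells (Homo sapiens) for antiproliferative activity, read by MTT assay, with a stated time of 72 h (a lower number here means a stronger inhibitor, a higher number a weaker inhibitor), compound 1 gives 82 nM.
Compound 2, `COc1ccc(-n2c(=O)c(C(=O)Nc3ccc(Oc4ccnc5[nH]ccc45)c(F)c3)cc3cccnc32)cc1`, in this assay compound 2 gives 540 nM.
Compound 3, `O=C(Nc1ccc(Oc2ccnc3[nH]ccc23)c(F)c1)c1cc2cccnc2n(-c2ccc(C(F)(F)F)cc2Cl)c1=O`, in this assay compound 3 gives 1360 nM.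

Compound 2 stands second highest of the three numbers. Its nearest neighbour is compound 3, reached by a 2.5-fold higher number from compound 2 to compound 3 (0.40 log units; beyond the scatter); its furthest is compound 1, from which it is reached by a 6.6-fold higher number from compound 1 to compound 2 (0.82 log units; beyond the scatter). The widest gap among the three is a 17-fold higher number from compound 1 to compound 3 (1.22 log units; beyond the scatter).

Compound 4, `COc1ccc(-n2c(=O)c(C(=O)Nc3ccc(Oc4ccnc5c4ccn5C)c(F)c3)cc3cccnc32)cc1`, has not yet been measured in this assay. It differs from compound 2 in one place: methyl in place of hydrogen on an aromatic nitrogen. All three measured steps concern the aryl group on the aromatic nitrogen of the shared core, not the five-membered ring where the methyl enters, so none of them bears directly on this change. The measured steps show that single changes on this scaffold can shift the number from modest to large amounts. Compound 4 is therefore estimated with a wide range, leaning toward a higher number than compound 2, a step of a 2.8-fold higher number from compound 2 to compound 4 (0.44 log units; beyond the scatter). The expected value for compound 4 in this assay is 1500 nM, between 200 nM and 12000 nM.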

Compound 4, half-maximal inhibitory concentration: 1290 nM
The estimate for compound 4 lay 1.2-fold (0.07 log units) above the measured number, within the range that was stated.
By their numbers in this assay, from the lowest: compound 1; then compound 2; then compounds 4 and 3 (each within the scatter of the next).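

Methyl in place of hydrogen on the aromatic nitrogen of the five-membered ring gives, in this assay, a 2.4-fold higher number from compound 2 to compound 4 (0.38 log units; beyond the scatter). For the compounds shown here, the earlier steps all changed the aryl group on the other aromatic nitrogen of the shared core, so this is the first sign that the part of the molecule carrying the five-membered ring also responds to a single change, and that even one added heavy atom there moves the number beyond the scatter, by a modest step and toward a weaker inhibitor. Nothing measured here speaks to why the number rises when the methyl enters.

The methyl step is seen on one aryl group only, the 4-methoxyphenyl of compound 2, so it remains open whether the same change would move the number as far on the 4-chlorophenyl of compound 1, the lowest number shown. Also open is how this nitrogen would respond to a longer chain such as ethyl, or to a chain ending in an amine or a carboxylic acid; only hydrogen and methyl are shown there.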